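The source may hold more compounds than are shown below. What is called first, only, known or untested is meant among the compounds shown, and "the series" means these compounds.

Compound 1 `Cc1cn2c(-c3cn[nH]c3)cnc2c(Nc2cc(Cc3nccs3)ns2)n1` is one of two compounds with a number in an ADME assay on the whole organism for pharmacokinetics, with Rattus norvegicus as the target, with a stated time of 6 h, at a dose of 10 mg/kg by the oral route; on this read-out lower numbers stand for lower exposure and higher numbers for higher exposure at the dose given. There compound 1 gives 1540 ng.h/mL, the highest of the two numbers, and compound 2 `Cc1cn2c(-c3cn[nH]c3)cnc2c(Nc2cc(Cc3ncccc3F)ns2)n1` gives 569 ng.h/mL. The two differ only at the saturated chain carbon bound to an aromatic carbon, and the step of a 2.7-fold lower number from compound 1 to compound 2 (0.43 log units; beyond the scatter) shows that putting 3-fluoropyridin-2-yl in place of 1,3-thiazol-2-yl lowered exposure by a modest margin that lies beyond the scatter.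

Compound 3 `Cc1cn2c(-c3cn[nH]c3)cnc2c(Nc2cc(Cc3cccc(F)n3)ns2)n1` has not been measured in this assay. It differs from compound 1 in one place: 6-fluoropyridin-2-yl in place of 1,3-thiazol-2-yl on a saturated chain carbon bound to an aromatic carbon. Within the data shown here, the only measured step that bears on this change is the one from compound 1 to compound 2, since it also removes 1,3-thiazol-2-yl from the same place and brings in a six-membered ring carrying fluorine. Among the measured compounds shown here, on that basis compound 3 is expected to sit below compound 1 in this assay, by a step of about a 2.4-fold lower number from compound 1 to compound 3 (0.37 log units; beyond the scatter), because a 2.7-fold lower number from compound 1 to compound 2 (0.43 log units; beyond the scatter) gives the one available precedent. Compound 3 is therefore estimated at 650 ng.h/mL, with a range from 300 ng.h/mL to 1400 ng.h/mL.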

Compound 3, area under the concentration-time curve: 2970 ng.h/mL
The estimate for compound 3 lay 4.6-fold (0.66 log units) below the measured number; the measured number lies above the stated range.
By their numbers in this assay, from the lowest: compound 2; then compounds 1 and 3 (each within the scatter of the next).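

The loss seen with compound 2 does not extend to every fluoropyridine: with 6-fluoropyridin-2-yl on the saturated chain carbon, the step of a 1.9-fold higher number from compound 1 to compound 3 (0.29 log units; within the scatter) stays within the scatter in this assay and so gives no resolved change from 1,3-thiazol-2-yl. The two fluoropyridines themselves are what separate here, since the step of a 5.2-fold higher number from compound 2 to compound 3 (0.72 log units; beyond the scatter) lies beyond the scatter and is the widest of the three steps among these compounds. Exposure at this position therefore depends on which of the two fluoropyridin-2-yl groups is present, and moving from the five-membered to a six-membered ring does not by itself lower the number, with compound 2 as the one case that shows a loss and compound 3 as the one that does not.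

No measurement at hand accounts for the gap between the two fluoropyridines. As far as these compounds go, how an unsubstituted pyridin-2-yl, a phenyl or a group carrying an amine on the same saturated chain carbon would compare with these three remains open.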